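This account rests on a few compounds, and the source may have more. Where it says the series, first, only, none or still open, it means among the compounds named here.

Measured so far in a functional assay on DU-145 cells (Homo sapiens) for antiproliferative activity, read by propidium iodide staining, with a stated time of 96 h; a lower number here means a stronger inhibitor, a higher number a weaker inhibitor:
- compound 1 `CC(O)(COc1ccc(OC(F)(F)F)cc1)C(=O)Nc1cccc(S(F)(F)(F)(F)F)c1`: 19100 nM
- compound 2 `CC(O)(CS(=O)(=O)c1ccc(S(F)(F)(F)(F)F)cc1)C(=O)Nc1cccc(S(F)(F)(F)(F)F)c1`: 17400 nM
- compound 3 `CC(O)(CS(=O)(=O)c1ccc(F)cc1)C(=O)Nc1cccc(S(F)(F)(F)(F)F)c1`: 48800 nM

Compound 3 stands highest of the three at 48800 nM, making it the weakest inhibitor so far, and both other compounds lie beyond the scatter from it. Compound 4 `CC(O)(CS(=O)(=O)c1ccccc1OC(F)(F)F)C(=O)Nc1cccc(S(F)(F)(F)(F)F)c1` carries 2-(trifluoromethoxy)phenyl in place of 4-fluorophenyl on a sulfonyl sulfur.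

Within the data shown here, the one measured step that bears on this change is a 2.8-fold higher number from compound 2 to compound 3 (0.45 log units; beyond the scatter), where a fluorine atom takes the place of a larger group on an aromatic carbon. Read in reverse, this single modest step suggests that a larger group in place of the fluorine-bearing ring may bring a lower number, although no measured step tests this exact exchange. A modest move to a lower number in this assay is therefore expected, with an estimated 2.2-fold lower number from compound 3 to compound 4 (0.35 log units; beyond the scatter). For compound 4 the estimated value is 22000 nM, within a range of 9000 nM to 50000 nM.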

Compound 4, half-maximal inhibitory concentration: 29100 nM
Compound 4: the middle estimate sits 1.3-fold (0.12 log units) below what was measured; low and high end bracket the measured number.
By their numbers in this assay, from the lowest: compounds 2, 1, 4 and 3 (each within the scatter of the next, the first and the last beyond it).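

In this assay, putting 2-(trifluoromethoxy)phenyl in place of 4-fluorophenyl on a sulfonyl sulfur gives a 1.7-fold lower number from compound 3 to compound 4 (0.22 log units; within the scatter) and so cannot be told apart from repeat scatter. The earlier step on this same ring, a 2.8-fold higher number from compound 2 to compound 3 (0.45 log units; beyond the scatter), lay beyond the scatter, so the compounds shown now hold one exchange at this position that separates and one that does not, and a higher count of heavy atoms in the entering group does not on its own bring a clear difference here. No evidence at hand bears on why this exchange reads as it does.

Among the sulfonyl compounds shown, compound 4 alone carries trifluoromethoxy, so the group and its place on the ring cannot be separated. As far as these compounds go, whether an amine or a carboxylic acid on this ring, or a longer chain in place of it on the sulfonyl sulfur, would move the number stays open.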